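This account rests on a few compounds, and the source may have more. Where it says the series, first, only, none or still open, it means among the compounds named here.

Measured so far in a functional assay on HT-1080 cells (Homo sapiens), read by transwell migration, with a stated time of 24 h, tested at 0.1 uM; on this read-out lower numbers stand for a stronger effect and higher numbers for a weaker effect at the one concentration tested:
compound 1 `CC(=O)OCc1ccc2oc(=O)c(C(=O)Oc3cccc(Cl)c3)cc2c1`: 95.2%
compound 2 `CC(=O)OCc1ccc2oc(=O)c(C(=O)Sc3ccccc3)cc2c1`: 89.5%
compound 3 `CC(=O)OCc1ccc2oc(=O)c(C(=O)Sc3cccc(Br)c3)cc2c1`: 79.6%

Compound 2 sits second highest of the three numbers, with a number 5.7 percentage points lower from compound 1 to compound 2 (within the scatter) and a number 9.9 percentage points lower from compound 2 to compound 3 (within the scatter) both within the scatter. The next compound is compound 4 `CC(=O)OCc1ccc2oc(=O)c(C(=O)Nc3cccc(Cl)c3)cc2c1`, differing from compound 2 as follows: (3-chlorophenyl)amino in place of phenylsulfanyl on a carbonyl carbon. Going by the values given here, no measured pair introduces a (3-chlorophenyl)amino group, so the exchange of the linking atom has no precedent here. Bromo in place of hydrogen on the aromatic ring gave a number 9.9 percentage points lower from compound 2 to compound 3 (within the scatter), and the only other measured step, a number 5.7 percentage points lower from compound 1 to compound 2 (within the scatter), likewise stayed within the scatter. On that basis only a small step, if any, is expected in this assay for compound 4, a number 4.5 percentage points lower from compound 2 to compound 4 (within the scatter). Compound 4 is estimated at 85%, within 70% to 98%.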

Compound 4, a percentage reported as activity, at one concentration (the size of the read-out at that concentration, not a potency): 79.6%
Estimate against measurement, compound 4: 5.4 percentage points above; low and high end bracket the measured number.
By their numbers in this assay, from the lowest: compounds 3, 4, 2 and 1 (each within the scatter of the next, the first and the last beyond it).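

In this assay, (3-chlorophenyl)amino on the carbonyl carbon stays level with both sulfur-linked groups (a number 9.9 percentage points lower from compound 2 to compound 4 (within the scatter); no change at the digits printed from compound 3 to compound 4 (within the scatter)). Against 3-chlorophenoxy, it gives the second step beyond the scatter at this position (a number 15.6 percentage points lower from compound 1 to compound 4 (beyond the scatter)), so the larger step is no longer confined to compound 3. No measurement here accounts for this.

Open, as far as these compounds go, is whether a benzylamino group or a plain alkyl amine on this carbonyl carbon would hold the number. From the compounds shown here alone, the separate contribution of the chloro group on (3-chlorophenyl)amino also remains open.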